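The source may report more compounds than this note shows. Statements on the series, on what has been measured and on what is new or still open speak of the compounds shown alone.

Working notes on the series. In a functional assay on SK-HEP1 cells (Homo sapiens) for inhibition, read by sulforhodamine B assay, with a stated time of 48 h (on this read-out higher numbers stand for weaker inhibition and lower numbers for stronger inhibition), compound 1 (`O=C(Nc1ccc2c(c1)N(Cc1ccc(C(=O)NO)cc1)CC2)Nc1ccc(Cl)c(C(F)(F)F)c1`) gives 4500 nM and compound 2 (`O=C(Nc1ccc(C(=O)NO)cc1)Nc1ccc(Cl)c(C(F)(F)F)c1`) gives 3800 nM. Going by the values given here, these two values lie within the scatter of each other, so compound 2 does not stand apart from compound 1 on the numbers so far.

Compound 3 (`O=C(CCCC(=O)Nc1ccc(NC(=O)Nc2ccc(Cl)c(C(F)(F)F)c2)cc1)NO`) follows from compound 2 by one change: ((3-(hydroxycarbamoyl)propyl)carbonyl)amino in place of hydroxycarbamoyl on an aromatic carbon, para to a large group (((3-(hydroxycarbamoyl)propyl)carbonyl)amino in place of hydroxycarbamoyl on an aromatic carbon). The hydroxycarbamoyl group is kept, now at the end of the entering group. Among the compounds with values here, no measured pair isolates a change of this kind, so the guide is thin. Compound 1, at 4500 nM, has a different structure from compound 2 and still falls within the scatter of it. On that basis, the expected step, a 1.3-fold lower number from compound 2 to compound 3 (0.10 log units; within the scatter), is estimated to stay within the scatter, with no firm direction. For compound 3 the expected value is 3000 nM, with an estimated range of 1000 nM to 9000 nM.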

Compound 3, half-maximal inhibitory concentration: > 10000 nM
Compound 3: no number, only a limit (the forecaster's own chance of this, stated with the estimate: 10%); middle value at least 3.3-fold (0.52 log units) from the limit.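

On an aromatic carbon para to a large group, ((3-(hydroxycarbamoyl)propyl)carbonyl)amino in place of hydroxycarbamoyl gives in this assay an at least 2.6-fold higher number from compound 2 to compound 3 (0.42 log units; beyond the scatter), so inhibition weakens on this change even though the hydroxycarbamoyl group is kept at the end of the entering group. Going by these compounds alone, this is the only step between compounds that differ in one place, and it lies beyond the scatter. The value of compound 3 is a limit and not a number, so the step has only a lower bound: the limit of > 10000 nM in this assay, at which 1 of the 3 values shown sits.

The compounds shown do not separate the effect of the amide link on the ring from that of the chain length. A shorter or longer chain ending in hydroxycarbamoyl, or a carboxylic acid at the chain end, would address that question.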